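A few compounds are considered here, and "the series" means these few. Any claim that something is new, unique, unknown or untested is made for them only; others in the source may bear on it.

Compound 1 `O=C(CCN1CCC(c2ccccc2)CC1)N1CCC[C@H]1c1nc2cc(Cl)c(Cl)cc2[nH]1` returns in an assay on a cell-free system (plasma) for inhibition of lysosomal Pro-X carboxypeptidase (Mus musculus) (a higher number here means a weaker inhibitor, a lower number a stronger inhibitor), only a limit of the assay, > 10000 nM (the limit of > 10000 nM in this assay, at which 1 of the 2 values shown sits). For the measured compounds named here, compound 2 `O=C(CCN1CCC(c2cnccn2)CC1)N1CCC[C@H]1c1nc2cc(Cl)c(Cl)cc2[nH]1`, carrying pyrazin-2-yl in place of phenyl on a saturated ring carbon, gives in this assay 8000 nM, the only full number among the two values shown. That exchange produced an at least 1.2-fold lower number from compound 1 to compound 2 (0.09 log units; that floor lies within the scatter). Compound 3 `Cn1nc(C2CCN(CCC(=O)N3CCC[C@H]3c3nc4cc(Cl)c(Cl)cc4[nH]3)CC2)cc1-c1cccnc1` changes the same place: a group of 12 heavy atoms (9 carbon, 3 nitrogen; one five-membered aromatic ring with 2 hetero atoms, one six-membered aromatic ring with 1 hetero atom) in place of a group of 6 heavy atoms (4 carbon, 2 nitrogen; one six-membered aromatic ring with 2 hetero atoms), on a saturated ring carbon. Going by the values given here, only the step from compound 1 to compound 2 bears on this position, and because its size rests on a limit of > 10000 nM in this assay, at which 1 of the 2 values shown sits, it sets no more than a modest downward floor within the scatter. One therefore expects in this assay no step beyond the scatter, or at most a small move toward a lower number. For compound 3 the estimate is 6000 nM, between 2000 nM and 15000 nM, which amounts to an expected 1.3-fold lower number from compound 2 to compound 3 (0.12 log units; within the scatter).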

Compound 3, half-maximal inhibitory concentration: 39 nM
Compound 3: middle estimate off by 150-fold (2.19 log units), on the high side; measured number outside the range, below it.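

The place on the saturated ring carbon proves far more responsive than compounds 1 and 2 could indicate: in this assay, the group with a five-membered and a six-membered aromatic ring gives a 210-fold lower number from compound 2 to compound 3 (2.31 log units; beyond the scatter). Measured against phenyl, the same group gives an at least 250-fold lower number from compound 1 to compound 3 (2.40 log units; beyond the scatter), and the true size of that step remains a floor because its starting value is a limit: the limit of > 10000 nM in this assay, at which 1 of the 3 values shown sits. Of the three groups shown at this place, only the one with two aromatic rings reaches a strong inhibitor.

The single step changes both rings at once, so the compounds shown do not tell whether the five-membered aromatic ring alone would carry the gain or whether both rings are needed. Going by these compounds, it also remains open how a carboxylic acid or an amine attached to this group would read.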